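This account rests on a few compounds, and the source may have more. Where it says the series, first, only, none or still open, it means among the compounds named here.

Two measured members share the core of compound 1 `Cc1ccc(C2=NN(c3nc(-c4ccc(F)cc4)cs3)C(c3ccc(F)cc3)C2)s1` and compound 2 `Cc1ccc(C2=NN(c3nc(-c4ccc(Br)cc4)cs3)C(c3ccc(F)cc3)C2)s1`, differing at a single aromatic position. In an ADME assay on NIH3T3 cells (Mus musculus) for cytotoxicity, read by XTT assay, with a stated time of 24 h (on this read-out lower numbers stand for stronger inhibition and higher numbers for weaker inhibition), compound 1 gives > 500 ug/mL, which is a limit of the assay and not a number. Compound 2 in this assay gives > 500 ug/mL, again a limit. The step that the two limits leave unreadable from compound 1 to compound 2 is therefore unreadable because of the limit of > 500 ug/mL in this assay, at which 2 of the 2 values shown sit. Compound 2 thus stands at the limit, with no number to set it against.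

Compound 3 `Cc1ccc(C2=NN(c3nc(-c4ccc(S(C)(=O)=O)cc4)cs3)C(c3ccc(F)cc3)C2)s1` carries methylsulfonyl in place of bromo on an aromatic carbon. Going by the values given here, the only measured step that bears on this change is the one between compound 1 and compound 2, and its size cannot be read, so no step beyond the scatter can be predicted in this assay in either direction. For compound 3 the value expected in this assay is 500 ug/mL, in a range from 150 ug/mL to 1000 ug/mL. This amounts to an expected step of a number no higher from compound 2 to compound 3 (the limit leaves the size open). The measured value will show whether this holds.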

Compound 3, half-maximal inhibitory concentration: 374 ug/mL
Compound 3: middle estimate off by 1.3-fold (0.13 log units), on the high side; the range from low to high includes it.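

In this assay, going from 4-bromophenyl to 4-(methylsulfonyl)phenyl gives an at least 1.3-fold lower number from compound 2 to compound 3 (0.12 log units; that floor lies within the scatter), and methylsulfonyl in place of fluoro gives an at least 1.3-fold lower number from compound 1 to compound 3 (0.12 log units; that floor lies within the scatter). Going by these compounds alone, compound 3 is the only one of the three compounds with a number instead of a limit, so this position can give a reading inside the range of the assay. Both steps are floors that lie within the scatter, so methylsulfonyl is not firmly separated from bromo or fluoro, and the steps' true sizes and the step between compound 1 and compound 2 remain unreadable because of the limit: the limit of > 500 ug/mL in this assay, at which 2 of the 3 values shown sit.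

Going by these compounds, whether an amine or a carboxylic acid at this position would give a number further from the limit remains open. So does whether a longer chain in place of methylsulfonyl would give a number on either side of that of compound 3.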